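Swapping the amine substituent on the shared core

The compounds below may be only part of what the source reports. "The series", "measured", "known", "first", "only" and "open" are said of these compounds alone.

Of the compounds shown here, three have been measured in an assay on CHO cells for displacement of a labelled ligand from 5-hydroxytryptamine receptor 1D (Homo sapiens); on this read-out lower numbers stand for stronger inhibition and higher numbers for weaker inhibition. Compound 1 `CN(Cc1cccs1)C1CCN(CCCc2c[nH]c3ccc(-n4cnnc4)cc23)CC1` gives 4.3 nM, the lowest of the three numbers. Compound 2 `OC[C@H](NC1CCN(CCCc2c[nH]c3ccc(Cn4cncn4)cc23)CC1)c1ccccc1` gives 23 nM, and compound 3 `COC[C@H](NC1CCN(CCCc2c[nH]c3ccc(Cn4cncn4)cc23)CC1)c1ccc(F)cc1` gives 5 nM; compound 3 lies within the scatter of compound 1, while compound 2 sits beyond it. Within the data shown here, the one measured step, a 4.6-fold lower number from compound 2 to compound 3 (0.66 log units; beyond the scatter), shows that a change of the group on the amine nitrogen can shift this assay by a modest amount.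

Compound 4 `c1ccc2c(c1)CCC2NCC1CCN(CCCc2c[nH]c3ccc(-n4cnnc4)cc23)CC1` is not yet measured. It differs from compound 1 in one place: ((2,3-dihydro-1H-inden-1-yl)amino)methyl in place of methyl((thiophen-2-yl)methyl)amino on a saturated ring carbon. Among the measured compounds shown here, no measured pair mirrors this change, so the step from compound 2 to compound 3 is only a loose guide to how much such a swap can matter. Since the shared core is kept, the expectation for compound 4 is a number close to that of compound 1, with a modest step possible in either direction, estimated as a 1.9-fold higher number from compound 1 to compound 4 (0.27 log units; within the scatter). Compound 4 is therefore expected to give about 8 nM, within a range of 2 nM to 30 nM.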

Compound 4, half-maximal inhibitory concentration: 1.1 nM
For compound 4 the middle estimate is 7.3-fold (0.86 log units) above the measured one; the whole stated range lies above it.
By their numbers in this assay, from the lowest: compound 4; then compounds 1 and 3 (each within the scatter of the next); then compound 2.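

In this assay, the thiophene-bearing group of compound 1 is not needed for a low number, since ((2,3-dihydro-1H-inden-1-yl)amino)methyl in its place gives a 3.9-fold lower number from compound 1 to compound 4 (0.59 log units; beyond the scatter). The earlier step concerned a group on an amine nitrogen; this one shows that the saturated ring carbon also tolerates a larger group with a carbon-only ring system and no sulfur. The change also brings in a hydrogen-bond donor that the leaving group lacks, so several features change in this single step. No measurement available here explains the shift.

The compounds shown do not separate the effect of the ring system from that of the amine hydrogen. A benzylamino methyl group or an N-methylated version of the entering group would be needed to tell these two apart.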